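The compounds below may be only part of what the source reports. "The series", "measured", "known", "first", "only" and "open" are said of these compounds alone.

Two compounds built on a shared core have been examined in a physicochemical assay for lipophilicity, read by HPLC, in phosphate buffer, measured as chromatographic lipophilicity, at pH 7.4; on this read-out higher numbers stand for higher lipophilicity and lower numbers for lower lipophilicity. Compound 1, with the structure `COc1ccc2nc(C)cc(OCCNc3cc(C)cc(C)c3)c2c1`, gives 6.93 in this assay. Compound 2, with the structure `COc1ccc2nc(C)cc(OCC(=O)Nc3ccc(Br)c(C)c3)c2c1`, gives 5.95 in this assay. Of these two numbers, compound 2 stands lowest, and the nearest number, that of compound 1, sits higher by a gap that goes beyond the usual scatter of repeated measurements. Among the compounds with values here, no step between compounds that differ in only one place has been recorded among the measured pair, so nothing can yet be said about what a single structural change does here.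

Compound 3, with the structure `COc1ccc2nc(C)cc(OCC(=O)Nc3nc(C)c(C)s3)c2c1`, has not been measured in this assay. It differs from compound 2 in one place: 4,5-dimethyl-1,3-thiazol-2-yl in place of 4-bromo-3-methylphenyl on an amide-type nitrogen. The 4-bromo-3-methylphenyl group leaves and the 4,5-dimethyl-1,3-thiazol-2-yl group enters on the amide-type nitrogen, whose other neighbour is the carbonyl carbon. For compound 3 a downward step of a number 0.95 log units lower from compound 2 to compound 3 (beyond the scatter) is expected, a step beyond the scatter. Compound 3 is therefore estimated at 5, within a range from 4.4 to 5.6.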

Compound 3, distribution coefficient: 4.24
Compound 3: the middle estimate sits 0.76 log units above what was measured; measured number outside the range, below it.
By their numbers in this assay, from the lowest: compound 3; then compound 2; then compound 1.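

Within the data shown here, replacing the 4-bromo-3-methylphenyl group with the 4,5-dimethyl-1,3-thiazol-2-yl group on the amide-type nitrogen gives the first one-place comparison, and in this assay the result is a large step, a number 1.71 log units lower from compound 2 to compound 3 (beyond the scatter), which shows that the group at this position can move the number well beyond the scatter. This happens even though the two groups are similar in heavy-atom count, 8 for the one that leaves and 7 for the one that enters. The entering ring also brings nitrogen and sulfur, with 2 hydrogen-bond acceptors where the leaving group has 0, but no evidence here links the step to any of these differences.

From the compounds shown here alone, this single swap changes the ring, removes the bromine and alters the methyl groups all at once, so the share of each in the step remains open. A plain phenyl group, a 3-methylphenyl group or an unsubstituted 1,3-thiazol-2-yl group on the same nitrogen would help to separate these changes, and whether the step carries over to the chain of compound 1 is also unresolved.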